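Swapping the Aryl Group: From Methoxyphenyl to Naphthyl

This account rests on a few compounds, and the source may have more. Where it says the series, first, only, none or still open, it means among the compounds named here.

Three compounds have been measured in a functional assay on MCF7 cells (Homo sapiens) for cytotoxicity, read by MTT assay, with a stated time of 72 h; a higher number here means a weaker inhibitor, a lower number a stronger inhibitor:

Compound 1 `CN(C)c1ccc(/C=C2\S/C(=N\c3nc(-c4ccc(Cl)cc4)cs3)NC2=O)cc1` gives 100 nM.
Compound 2 `Cc1ccc(/C=C2\S/C(=N\c3nc(-c4ccc(Cl)cc4)cs3)NC2=O)cc1` gives 400 nM.
Compound 3 `COc1ccc(/C=C2\S/C(=N\c3nc(-c4ccc(Cl)cc4)cs3)NC2=O)cc1` gives 100 nM.

For the measured compounds named here, all three share one core and differ only in the single group carried on the outer aromatic ring. Compound 3 stands level with compound 1 at the digits shown, the two together giving the lowest numbers of the set; the step of no change at the digits printed from compound 1 to compound 3 (within the scatter) lies within the scatter. Its furthest neighbour is compound 2, with a 4.0-fold lower number from compound 2 to compound 3 (0.60 log units; beyond the scatter), the mirror of a 4.0-fold higher number from compound 1 to compound 2 (0.60 log units; beyond the scatter).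

Compound 4 `O=C1N/C(=N/c2nc(-c3ccc(Cl)cc3)cs2)S/C1=C\c1ccc2ccccc2c1` is not yet measured. Its change from compound 3 is naphthalen-2-yl in place of 4-methoxyphenyl on a double-bonded chain carbon bound to a double-bonded ring carbon. Going by the values given here, no measured step exchanges the whole ring; the three known steps only swap one group on it, and the largest of them, a 4.0-fold higher number from compound 1 to compound 2 (0.60 log units; beyond the scatter), is modest. The number for compound 4 is therefore expected to move by a 3.0-fold higher number from compound 3 to compound 4 (0.48 log units; beyond the scatter), toward a somewhat higher value, with wide uncertainty. Compound 4 is estimated at 300 nM, in a range from 80 nM to 1200 nM.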

Compound 4, half-maximal inhibitory concentration: 300 nM
Compound 4: the middle estimate sits on the measured number at the digits printed; the measured number falls inside the stated range.
By their numbers in this assay, from the lowest: compounds 1 and 3 (each within the scatter of the next); then compounds 4 and 2 (each within the scatter of the next).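

Exchanging the whole ring rather than one group on it, naphthalen-2-yl in this assay gives a 3.0-fold higher number from compound 3 to compound 4 (0.48 log units; beyond the scatter) and a 3.0-fold higher number from compound 1 to compound 4 (0.48 log units; beyond the scatter), while a 1.3-fold lower number from compound 2 to compound 4 (0.12 log units; within the scatter) leaves it indistinguishable from the 4-methylphenyl compound. This position therefore accepts a second six-membered aromatic ring and keeps a measurable effect, and among these four compounds the 4-methoxyphenyl and 4-(dimethylamino)phenyl groups give lower numbers than both naphthalen-2-yl and 4-methylphenyl. Nothing measured here explains why these groups differ.

Going by these compounds, whether another two-ring group, such as naphthalen-1-yl or a quinoline, would give a number closer to that of compound 3 remains open. So does the effect of a hydroxyl, an amine or a carboxylic acid on the outer ring.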